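A few compounds are considered here, and "the series" means these few. Any claim that something is new, unique, unknown or untested is made for them only; others in the source may bear on it.

Compound 2 `Nc1ccc(-c2nnn(Cc3ccc(C(=O)NO)cc3)n2)cc1` gives 1 nM. Compound 1 `O=C(NO)c1ccc(Cn2nnc(-c3ccc(S(F)(F)(F)(F)F)cc3)n2)cc1` gives 25 nM.

For the measured compounds named here, in an assay on Sf9 cells for inhibition of protein deacetylase HDAC6 (Homo sapiens), read by fluorescence (on this read-out higher numbers stand for weaker inhibition and lower numbers for stronger inhibition), compound 2 stands lowest of the two measured compounds; the only measured step is a 25-fold lower number from compound 1 to compound 2 (1.40 log units; beyond the scatter). Compound 3 `NCc1ccc(-c2nnn(Cc3ccc(C(=O)NO)cc3)n2)cc1` differs from compound 2 by aminomethyl in place of amino on an aromatic carbon. Going by the values given here, that measured step exchanged a different group at the same aromatic carbon, so it bears only loosely on this change; no measured pair tells how lengthening amino to aminomethyl acts here. Compound 3 is therefore expected to move only modestly, a 3.0-fold higher number from compound 2 to compound 3 (0.48 log units; beyond the scatter). Compound 3 is estimated at 3 nM, within 0.7 nM to 15 nM.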

Compound 3, half-maximal inhibitory concentration: 2 nM
Estimate against measurement, compound 3: 1.5-fold (0.18 log units) above; measured number inside the range.
By their numbers in this assay, from the lowest: compounds 2 and 3 (each within the scatter of the next); then compound 1.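

In this assay, moving from amino to aminomethyl on this aromatic carbon gives a 2.0-fold higher number from compound 2 to compound 3 (0.30 log units; within the scatter), so the two compounds cannot be told apart. Compared with the group on compound 1, aminomethyl also gives a 13-fold lower number from compound 1 to compound 3 (1.10 log units; beyond the scatter), which shows that the low numbers here do not depend on amino alone. No available evidence accounts for these results.

On these data alone, whether a longer aminoethyl chain, a dimethylamino group or a carboxylic acid on this carbon would keep the number as low remains open.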